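Swapping the drawn configuration in a diethyl-substituted urea

The source may report more compounds than this note shows. Statements on the series, on what has been measured and on what is new or still open speak of the compounds shown alone.

Measured compounds:
compound 1, `CCc1ccccc1NC(=O)N[C@@H](C)c1ccccc1`: 95%
compound 2, `CCc1cccc(CC)c1NC(=O)N[C@H](C)c1ccccc1`: 99%

In an ADME assay on the whole organism with Oryza sativa as the target, tested at 10 uM (a lower number here means a stronger effect, a higher number a weaker effect of the compound at the concentration tested), compound 1 gives 95%, and in the same test compound 2 gives 99%. The two numbers sit close together, their gap lying within the usual scatter of this kind of measurement, so neither compound can be called stronger or weaker than the other on this evidence; both leave a large share of the read-out untouched.

Compound 3, `CCc1cccc(CC)c1NC(=O)N[C@@H](C)c1ccccc1`, has not yet been tested. Compared with compound 2, (the two compounds have the same atoms and bonds and differ only in configuration as drawn: 1 of 1 stereo elements differ; a stereocentre at a saturated chain carbon is drawn R in compound 2 and S in compound 3). Within the data shown here, with only two measured compounds, nothing is known here about how such a change in drawn configuration shifts the read-out. Compound 3 is therefore expected to stay near compound 2, with a step of a number 3 percentage points lower from compound 2 to compound 3 (within the scatter) that is not expected to exceed the scatter. The estimate for compound 3 is 96%, within the range 87% to 103%.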

Compound 3, a percentage reported as activity, at one concentration (the size of the read-out at that concentration, not a potency): 83%
The estimate for compound 3 lay 13 percentage points above the measured number; measured number outside the range, below it.
By their numbers in this assay, from the lowest: compound 3; then compounds 1 and 2 (each within the scatter of the next).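

In this assay, the drawn configuration at the saturated chain carbon proves able to move the read-out, with a number 16 percentage points lower from compound 2 to compound 3 (beyond the scatter). That step can be assigned to the stereocentre alone, because nothing else changes: the fact that compounds 2 and 3 differ only in the configuration as drawn. The added ethyl also counts when the configuration stays the same, since ethyl in place of hydrogen on an aromatic carbon gives a number 12 percentage points lower from compound 1 to compound 3 (beyond the scatter), something the first pair could not show, as compounds 1 and 2 differ in both places at once.

Both steps rest on a single pair each and on one concentration, so they describe the size of the read-out there and not a potency. As far as these compounds go, whether the gap between the two configurations would persist with a propyl chain in place of each ethyl, or with an amine on the shared core, remains open.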